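Sulfur substituent exchange from compound 3 to compound 4

A few compounds are considered here, and "the series" means these few. Any claim that something is new, unique, unknown or untested is made for them only; others in the source may bear on it.

Values so far in a physicochemical assay for solubility, using the shake flask method, in phosphate buffer, with a stated time of 24 h, at pH 7.4; on this read-out lower numbers stand for lower solubility and higher numbers for higher solubility
- compound 1 `COc1cccc(C(C)Sc2nc3c(cnn3C)c(=O)n2-c2ccccc2)c1` gives < 2000 nM as a limit
- compound 2 `CC(Sc1nc2c(cnn2C)c(=O)n1-c1ccccc1)c1cccnc1` gives 209000 nM as a number
- compound 3 `Cn1ncc2c(=O)n(-c3ccccc3)c(SCc3cccc(F)c3)nc21` gives < 700 nM as a limit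

Compound 3 stands at < 700 nM as a limit and not a number. Compound 1 stands at < 2000 nM as a limit as well. Only compound 2 of the three has a number.

Compound 4 `CC(Sc1nc2c(cnn2C)c(=O)n1-c1ccccc1)c1cncnc1` has not yet been measured. Its difference from compound 3 is 1-(pyrimidin-5-yl)ethyl in place of 3-fluorobenzyl on a sulfur with 1-(pyrimidin-5-yl)ethyl in place of 3-fluorobenzyl on a sulfur.

Among the measured compounds shown here, two measured steps bear on this change, and both are large. Pyridin-3-yl in place of 3-methoxyphenyl gave an at least 100-fold higher number from compound 1 to compound 2 (2.01 log units; beyond the scatter) on the chain carbon. The exchange of 1-(pyridin-3-yl)ethyl for 3-fluorobenzyl on the sulfur gave an at least 290-fold lower number from compound 2 to compound 3 (2.47 log units; beyond the scatter) and the step to compound 4 runs the opposite way, with a different entering group. The closest reference is compound 2 at 209000 nM with its 1-(pyridin-3-yl)ethyl on that sulfur.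

The step expected in this assay is an at least 280-fold higher number from compound 3 to compound 4 (2.45 log units; beyond the scatter) and it should be large and upward. For compound 4 the estimate is 200000 nM with an expected range of 50000 nM to 700000 nM in this read-out.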

Compound 4, solubility: 264000 nM
Beside the measured number, compound 4's estimate is 1.3-fold (0.12 log units) below it; the range from low to high includes it.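

In this assay, pyrimidin-5-yl in place of pyridin-3-yl on the saturated chain carbon gives a 1.3-fold higher number from compound 2 to compound 4 (0.10 log units; within the scatter), so the two rings cannot be told apart on this read-out. On the sulfur, 1-(pyrimidin-5-yl)ethyl in place of 3-fluorobenzyl gives an at least 370-fold higher number from compound 3 to compound 4 (2.57 log units; beyond the scatter), and pyrimidin-5-yl in place of 3-methoxyphenyl on the chain carbon gives an at least 130-fold higher number from compound 1 to compound 4 (2.12 log units; beyond the scatter); across these four compounds, the two with a ring holding hetero atoms carry numbers and the two with a ring of carbon only sit at limits, with none going against this. The step out of compound 3 gives only a minimum size, as compound 3 is held at a limit and not a number: the limit of < 700 nM in this assay, at which 1 of the 4 values shown sits.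

The step from 3-fluorobenzyl to 1-(pyrimidin-5-yl)ethyl exchanges the ring and adds the branching methyl together, so a pyrimidin-5-ylmethyl group on the sulfur would be needed to separate the two. Also open, going by these compounds, is how far this level holds when the pyrimidin-5-yl ring carries a further group, such as a morpholine or a carboxylic acid.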